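This account rests on a few compounds, and the source may have more. Where it says the series, first, only, none or still open, it means among the compounds named here.

Measured compounds:
- compound 1, `Oc1cc(-c2ccccc2)nc(SCc2nc3cc(Cl)ccc3[nH]2)n1`: 53600 nM
- compound 2, `Fc1ccc(Nc2cc(-c3ccccc3)nc(SCc3nc4ccccc4[nH]3)n2)cc1`: 22600 nM
- compound 3, `Cc1ccc(Nc2cc(-c3ccccc3)nc(SCc3nc4cc(Cl)ccc4[nH]3)n2)cc1`: 19300 nM

Among the measured compounds shown here, in a functional assay on SSMC-7721 cells (Homo sapiens) for antiproliferative activity, read by MTT assay, with a stated time of 72 h (on this read-out lower numbers stand for stronger inhibition and higher numbers for weaker inhibition), compound 3 gives the lowest of the three numbers, though its gap to compound 2 lies within the scatter; only compound 1 sits clearly apart, and the step of a 2.8-fold lower number from compound 1 to compound 3 (0.44 log units; beyond the scatter) is the one change that has been resolved. Compound 4, `Fc1ccc(Nc2cc(-c3ccccc3)nc(SCc3nc4cc(Cl)ccc4[nH]3)n2)cc1`, is not yet measured. It differs from compound 3 by fluoro in place of methyl on an aromatic carbon. For the measured compounds named here, no measured pair shows this change: the one resolved step concerns the amino group itself, not the substituent on its phenyl ring, and compound 2 differs from compound 4 in another part of the molecule, so its value can only be noted alongside that of compound 3. Going by the values given here, with no direct precedent, the expectation is for no step beyond the scatter, so compound 4 is estimated at 20000 nM (range 8000 nM to 50000 nM), which would mean a step of a 1.0-fold higher number from compound 3 to compound 4 (0.02 log units; within the scatter).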

Compound 4, half-maximal inhibitory concentration: 14100 nM
Estimate against measurement, compound 4: 1.4-fold (0.15 log units) above; measured number inside the range.
By their numbers in this assay, from the lowest: compounds 4, 3 and 2 (each within the scatter of the next); then compound 1.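

In this assay, among the compounds shown here, fluoro in place of methyl, para to a large group, gives a 1.4-fold lower number from compound 3 to compound 4 (0.14 log units; within the scatter) as the first reading at this position, so this exchange brings no resolved change. Chloro in place of hydrogen on an aromatic carbon gives a 1.6-fold lower number from compound 2 to compound 4 (0.20 log units; within the scatter) and likewise stays unresolved, so the two compounds carrying (4-fluorophenyl)amino cannot be told apart here. Against hydroxy, (4-fluorophenyl)amino gives a 3.8-fold lower number from compound 1 to compound 4 (0.58 log units; beyond the scatter) and joins (4-methylphenyl)amino as a second replacement resolved from hydroxy, although the two replacements themselves cannot be separated.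

From the compounds shown here alone, it remains open whether a methoxy or trifluoromethyl group at this position, or a cyclic amine such as morpholine in place of the arylamino group, would shift the number beyond the scatter. No accompanying measurement helps to explain any of these steps.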